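Working notes: from compound 2 to compound 4

A few compounds are considered here, and "the series" means these few. Any claim that something is new, unique, unknown or untested is made for them only; others in the source may bear on it.

Values in a functional assay on SW-620 cells (Homo sapiens) for cytotoxicity, read by MTT assay, with a stated time of 3 days (a lower number here means that less compound is needed, a higher number that more compound is needed for the effect), for the measured compounds:
- compound 1 `O=C1/C(=C/c2cccc(Cl)c2)c2ccccc2N1c1c(Cl)cccc1Cl` gives 50 ug/mL
- compound 2 `O=C1/C(=C/c2ccc(Cl)cc2Cl)c2ccccc2N1c1c(Cl)cccc1Cl` gives 2 ug/mL
- compound 3 `COc1ccc(/C=C2/C(=O)N(c3c(Cl)cccc3Cl)c3ccccc32)cc1` gives > 100 ug/mL, which is a limit of the assay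

Compound 2 stands lowest of the three, and its nearest neighbour is compound 1, with a 25-fold lower number from compound 1 to compound 2 (1.40 log units; beyond the scatter) as the measured step. Compound 4 `O=C1/C(=C/c2ccc(F)cc2)c2ccccc2N1c1c(Cl)cccc1Cl` carries 4-fluorophenyl in place of 2,4-dichlorophenyl on a double-bonded chain carbon bound to a double-bonded ring carbon. All measured steps fall at this same place. Leaving the 2,4-dichlorophenyl of compound 2 gave an at least 50-fold higher number from compound 2 to compound 3 (1.69 log units; beyond the scatter), a large rise. The step of an at least 2.0-fold higher number from compound 1 to compound 3 (0.30 log units; that floor lies within the scatter) has a floor within the scatter, so it does not separate those two groups. Neither measured group matches 4-fluorophenyl, so the size of the step remains uncertain. A rise beyond the scatter is expected, estimated as a 10-fold higher number from compound 2 to compound 4 (1.00 log units; beyond the scatter) in this assay for this change. For compound 4 the estimated value is 20 ug/mL, with an expected range from 4 ug/mL to 100 ug/mL in this assay.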

Compound 4, concentration for half-maximal effect: 5 ug/mL
Beside the measured number, compound 4's estimate is 4.0-fold (0.60 log units) above it; the measured number falls inside the stated range.
By their numbers in this assay, from the lowest: compound 2; then compound 4; then compound 1. At a limit, above all of these: compound 3.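

In this assay, this position on a double-bonded chain carbon bound to a double-bonded ring carbon does not depend on the 2,4-dichlorophenyl of compound 2 for a low number: 4-fluorophenyl gives a 2.5-fold higher number from compound 2 to compound 4 (0.40 log units; beyond the scatter), a modest rise. A single halogen on the phenyl is not enough to settle the outcome, since 4-fluorophenyl in place of 3-chlorophenyl gives a 10-fold lower number from compound 1 to compound 4 (1.00 log units; beyond the scatter), while fluoro in place of methoxy on an aromatic carbon gives an at least 20-fold lower number from compound 3 to compound 4 (1.30 log units; beyond the scatter). That last step is only a floor, with compound 3 held at a limit of the assay: the limit of > 100 ug/mL in this assay, at which 1 of the 4 values shown sits.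

The compounds shown do not separate the identity of the halogen from its ring position, and 4-chlorophenyl and 3-fluorophenyl are not among them. From the compounds shown here alone, how an amine or a carboxylic acid on this phenyl would read also remains open.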